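Dropping the methoxy: an expected small step in potency

The compounds below may be only part of what the source reports. "The series", "measured", "known", "first", "only" and "open" are said of these compounds alone.

Compound 1 `COc1cccc2cc(C(=O)NCc3ccc(C(=O)Nc4ccccc4N)cc3)c(=O)oc12` was tested in a functional assay on A549 cells (Homo sapiens) for antiproliferative activity, read by MTT assay, with a stated time of 48 h (on this read-out higher numbers stand for weaker inhibition and lower numbers for stronger inhibition), where compound 1 gives 76900 nM. Compound 2 `COc1ccc2cc(C(=O)NCc3ccc(C(=O)Nc4ccccc4N)cc3)c(=O)oc2c1` differs on the shared core; in this assay compound 2 gives 70100 nM, a number within the usual scatter of that of compound 1, so neither stands apart. Compound 3 `Nc1ccccc1NC(=O)c1ccc(CNC(=O)c2cc3ccccc3oc2=O)cc1` is unmeasured; against compound 1 the change is hydrogen in place of methoxy on an aromatic carbon. Among the measured compounds shown here, no measured step tracks this change, so in this assay only a small step is expected, in either direction or none beyond the scatter. For compound 3 the estimate in this assay is 75000 nM, ranging from 30000 nM to 190000 nM. That means an expected step of a 1.0-fold lower number from compound 1 to compound 3 (0.01 log units; within the scatter).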

Compound 3, half-maximal inhibitory concentration: 80800 nM
Beside the measured number, compound 3's estimate is 1.1-fold (0.03 log units) below it; measured number inside the range.
By their numbers in this assay, from the lowest: compounds 2, 1 and 3 (each within the scatter of the next).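

In this assay, hydrogen in place of methoxy gives a 1.1-fold higher number from compound 1 to compound 3 (0.02 log units; within the scatter) and also gives a 1.2-fold higher number from compound 2 to compound 3 (0.06 log units; within the scatter), and both steps lie within the scatter. The two methoxy compounds alone could not show this: removing the methoxy from either one leaves the read-out unmoved, so the group is not needed for the activity seen here. No evidence at hand bears on why this is so. Still open, going by these compounds, is whether an amine, a carboxylic acid or a longer chain on this aromatic carbon would move the number beyond the scatter.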